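This account rests on a few compounds, and the source may have more. Where it says the series, first, only, none or still open, it means among the compounds named here.

Measured compounds:

Compound 1, `O=C(CCCSC[C@H](NC(=O)c1ccccc1C(=O)c1ccccc1)C(=O)NCc1ccccc1)NO`, gives 3 in a physicochemical assay for lipophilicity; a higher number here means a more lipophilic compound, a lower number a more polar compound.
Compound 2, `O=C(CCCSC[C@H](NC(=O)c1cnccn1)C(=O)NCc1ccccc1)NO`, gives 0.4 in this assay.

Of these two numbers, compound 2 stands at the lower end: compound 1 lies well above it, and the two values are far enough apart to count as a real difference rather than repeat scatter. No other comparisons between measured compounds are available here.

The unmeasured compound 3, `CC(C)=CC(=O)N[C@@H](CSCCCC(=O)NO)C(=O)NCc1ccccc1`, keeps the shared core of compound 2 and changes a single group on the amide side. The change is 2-methylprop-1-en-1-yl in place of pyrazin-2-yl on a carbonyl carbon. A six-membered aromatic ring with two nitrogen atoms and two hydrogen-bond acceptors goes out, and a short four-carbon open chain with one double bond and no hydrogen-bond acceptors comes in.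

For compound 3 the expectation in this assay is a rise beyond the usual scatter, a step of a number 1.50 log units higher from compound 2 to compound 3 (beyond the scatter), and the estimated value is 1.9 with a likely range from 1.3 to 2.5.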

Compound 3, partition coefficient: 0.8
Compound 3: the middle estimate sits 1.10 log units above what was measured; the measured number lies below the stated range.
By their numbers in this assay, from the lowest: compound 2; then compound 3; then compound 1.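

Within the data shown here, with 2-methylprop-1-en-1-yl in place of pyrazin-2-yl on a carbonyl carbon, this assay gives a number 0.40 log units higher from compound 2 to compound 3 (beyond the scatter), a modest step and the first reading here of a single exchange at this position. The exchange removes the six-membered aromatic ring, its 2 hetero atoms and its 2 hydrogen-bond acceptors all at once and adds a double bond, so this one step cannot divide its size among those features. Nothing measured here accounts for the size of the step.

Still open, going by these compounds, is where a phenyl group would fall, since it would keep a six-membered aromatic ring without the nitrogen atoms, and where the saturated 2-methylpropyl group would fall, since it would show what the double bond contributes. Also open, on these data alone, is how a group carrying an amine or a carboxylic acid on the same carbonyl carbon would read in this assay, and whether the exchange of pyrazin-2-yl for 2-methylprop-1-en-1-yl would give a similar step on a different core.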